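A few compounds are considered here, and "the series" means these few. Any claim that something is new, unique, unknown or untested is made for them only; others in the source may bear on it.

Measured compounds:
compound 1 `Cc1c(C(=O)O)oc2ccc(N(Cc3ccccc3)S(=O)(=O)c3ccc(Cl)cc3)cc12`, 9130 nM
compound 2 `Cc1c(C(=O)O)oc2ccc(N(Cc3ccc(Cl)cc3)S(=O)(=O)c3ccc(Cl)cc3)cc12`, 3670 nM

In a functional assay on HCT-116 cells (Homo sapiens) for inhibition, read by MTT assay, with a stated time of 72 h (a higher number here means a weaker inhibitor, a lower number a stronger inhibitor), compound 1 has the highest of the two numbers; its nearest neighbour is compound 2, and the move from one to the other, chloro in place of hydrogen on an aromatic carbon, gives a 2.5-fold lower number from compound 1 to compound 2 (0.40 log units; beyond the scatter). Compound 3 `Cc1c(C(=O)O)oc2ccc(N(Cc3ccccc3)S(=O)(=O)c3ccc(C(F)(F)F)cc3)cc12` differs from compound 1 by trifluoromethyl in place of chloro on an aromatic carbon. Among the compounds with values here, no measured step touches this position, so the one step on record, at the benzyl ring, offers no guide. Compound 3 is therefore expected to change little, a 1.3-fold lower number from compound 1 to compound 3 (0.12 log units; within the scatter), and its estimated value is 7000 nM with a range from 2500 nM to 25000 nM.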

Compound 3, half-maximal inhibitory concentration: 4130 nM
Compound 3: the middle estimate sits 1.7-fold (0.23 log units) above what was measured; the measured number falls inside the stated range.
By their numbers in this assay, from the lowest: compounds 2 and 3 (each within the scatter of the next); then compound 1.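

In this assay, the aromatic carbon para to a large group proves open to change: trifluoromethyl in place of chloro gives a 2.2-fold lower number from compound 1 to compound 3 (0.34 log units; beyond the scatter), a modest step beyond the scatter. Four heavy atoms can therefore stand where one stood without the number rising. Nothing available explains this step. As far as these compounds go, whether a nitrile, a methoxy group or an amine at this carbon would lower the number further remains open. So does whether trifluoromethyl here would add to the chloro on the benzyl ring of compound 2.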